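Swapping a naphthyl amide for a phenyl amide

The source may report more compounds than this note shows. Statements on the series, on what has been measured and on what is new or still open speak of the compounds shown alone.

Three related compounds have been tested so far in an assay on a subcellular fraction from brain with sodium-dependent dopamine transporter (Rattus norvegicus) as the target; on this read-out higher numbers stand for weaker inhibition and lower numbers for stronger inhibition. Compound 1 `CC(=O)OCCSC[C@@H]1CN(C)CC[C@@H]1c1ccc(Cl)cc1` gives 46 nM in this assay. Compound 2 `CN1CC[C@@H](c2ccc(Cl)cc2)[C@@H](CSCC(=O)Nc2cccc3ccccc23)C1` gives 102 nM in this assay, which places it second highest of the three numbers: compound 1 sits below it by a margin beyond the usual scatter, and compound 3 `CN1CC[C@@H](c2ccc(Cl)cc2)[C@H](CSCCOC(=O)c2ccccc2)C1`, which gives 378 nM in this assay, sits above it by a larger margin, also beyond the scatter.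

Compound 4 `CN1CC[C@@H](c2ccc(Cl)cc2)[C@@H](CSCC(=O)Nc2ccccc2)C1` has not yet been measured. It differs from compound 2 in one place: phenyl in place of naphthalen-1-yl on an amide-type nitrogen. Going by the values given here, no pair among the measured compounds differs in exactly this way, so no measured step can guide the expectation directly. The change keeps the amide and removes one of the two fused aromatic rings, and the expectation is a modest shift towards weaker inhibition, possibly no larger than the scatter. The step from compound 2 to compound 4 is estimated as a 1.6-fold higher number from compound 2 to compound 4 (0.20 log units; within the scatter). Compound 4 is expected to give about 160 nM in this assay, with a likely range from 55 nM to 500 nM.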

Compound 4, inhibition constant: 80 nM
Beside the measured number, compound 4's estimate is 2.0-fold (0.30 log units) above it, within the range that was stated.
By their numbers in this assay, from the lowest: compounds 1, 4 and 2 (each within the scatter of the next, the first and the last beyond it); then compound 3.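

In this assay, going by these compounds alone, the first direct reading at this position is a swap of naphthalen-1-yl for phenyl on the amide-type nitrogen, which gives a 1.3-fold lower number from compound 2 to compound 4 (0.11 log units; within the scatter) and so leaves the two compounds indistinguishable. One of the two fused aromatic rings can therefore be removed here without a shift that stands out from the usual variation between repeat measurements, and the single phenyl ring serves as well as the larger naphthalen-1-yl group on this read-out. The data shown offer no measurement that could explain this result.

As far as these compounds go, whether any aromatic ring is needed on this nitrogen remains open, and a small methyl group or a plain hydrogen there would test that. It is also unknown how a benzyl group, with one extra carbon between the nitrogen and the ring, would compare.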